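Hydrogen in Place of Chlorophenyl on the Amide Nitrogen

The source may hold more compounds than are shown below. What is called first, only, known or untested is meant among the compounds shown, and "the series" means these compounds.

Compound 1 `O=C1COc2ccc(-c3ccc(O)cc3)cc2N1`: > 40000 nM
Compound 2 `COc1cccc(N2C(=O)COc3ccc(-c4cnc5ccccc5c4)cc32)c1`: 8240 nM
Compound 3 `O=C1COc2ccc(-c3cccc(NS(=O)(=O)c4ccc(F)cc4)c3)cc2N1c1ccc(Cl)cc1`: 23900 nM

Three compounds share the core of compound 1 and were tested in a functional assay on HCT-116 cells (Homo sapiens) for antiproliferative activity, read by MTT assay, with a stated time of 72 h; a lower number here means a stronger inhibitor, a higher number a weaker inhibitor. Compound 1 reaches only a limit of the assay, (the limit of > 40000 nM in this assay, at which 1 of the 3 values shown sits), and no number is reported for it. Of the two numbers that are reported, compound 3 holds the higher one with 23900 nM, while compound 2 gives the lower one with 8240 nM; the gap between them lies beyond the usual scatter.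

Compound 4 `O=C1COc2ccc(-c3cccc(NS(=O)(=O)c4ccc(F)cc4)c3)cc2N1` has not yet been measured in this assay. It differs from compound 3 in one place: hydrogen in place of 4-chlorophenyl on an amide-type nitrogen in a ring. Among the compounds measured so far, only compound 1 carries a hydrogen on that amide-type nitrogen, and it sits at the limit. The step from compound 3 to compound 4 is therefore expected to run toward a weaker inhibitor, by roughly a 1.9-fold higher number from compound 3 to compound 4 (0.27 log units; within the scatter), with a real chance that only a limit is reported. Compound 4 is expected to give about 45000 nM, within a range from 15000 nM to 120000 nM.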

Compound 4, half-maximal inhibitory concentration: > 40000 nM
Compound 4 ended at the assay's limit (the forecaster's own chance of this, stated with the estimate: 55%); the middle value does not contradict the limit.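

In this assay compound 4 gives > 40000 nM, which is a limit of the assay and not a number. Hydrogen in place of 4-chlorophenyl on the amide-type nitrogen in a ring is the first single change here that can be read, and it gives an at least 1.6-fold higher number from compound 3 to compound 4 (0.22 log units; that floor lies within the scatter), so the limit leaves the true size of the step unknown. Compound 4 joins compound 1 as a second compound with hydrogen on that nitrogen that stands at the limit: the limit of > 40000 nM in this assay, at which 2 of the 4 values shown sit.

Going by these compounds, whether a small alkyl group such as methyl, or a benzyl group, on that nitrogen would return a number rather than a limit stays open. Also open, on these data alone, is whether the chlorine or the ring itself carries the difference, which a plain phenyl group at that nitrogen could separate.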